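Replacing pyridin-3-yl with 2-fluorophenyl in a cytotoxic series

The source may report more compounds than this note shows. Statements on the series, on what has been measured and on what is new or still open speak of the compounds shown alone.

In a functional assay on HL-60 cells (Homo sapiens) for cytotoxicity, read by WST assay, with a stated time of 48 h (on this read-out lower numbers stand for stronger inhibition and higher numbers for weaker inhibition), compound 1, `Oc1ccccc1/C=C/C[C@H]1C[C@@H]([C@@H](O)c2ccccc2)CO[C@@H]1c1ccccc1`, gives 10800 nM. Compound 2, `O[C@@H](c1ccccc1)[C@H]1CO[C@H](c2ccccc2)[C@@H](C/C=C/c2cccnc2)C1`, gives > 100000 nM, which is a limit and not a number. Compound 2 therefore stands at the limit of > 100000 nM in this assay, at which 1 of the 2 values shown sits.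

Compound 3, `O[C@@H](c1ccccc1)[C@H]1CO[C@H](c2ccccc2)[C@@H](C/C=C/c2ccccc2F)C1`, carries 2-fluorophenyl in place of pyridin-3-yl on a double-bonded chain carbon bound to a double-bonded chain carbon.

Going by the values given here, only one measured step bears on this change: an at least 9.2-fold higher number from compound 1 to compound 2 (0.96 log units; beyond the scatter). That step put pyridin-3-yl in place of 2-hydroxyphenyl at the same place, so the new change partly reverses it. The entering 2-fluorophenyl is a ring of carbon only, as is the 2-hydroxyphenyl of compound 1 at 10800 nM, but the two groups are not the same, so the recovery may be only partial. The size of the step also remains uncertain, since the starting point is only a limit. In this assay, a move to a lower number, beyond the scatter, is therefore expected: an at least 5.0-fold lower number from compound 2 to compound 3 (0.69 log units; beyond the scatter). For compound 3, the estimated value is 20000 nM, with an expected range of 6000 nM to 70000 nM.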

Compound 3, half-maximal inhibitory concentration: 9530 nM
Compound 3: middle estimate off by 2.1-fold (0.32 log units), on the high side; the measured number falls inside the stated range.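

In this assay, 2-fluorophenyl in place of pyridin-3-yl, on a double-bonded chain carbon bound to a double-bonded chain carbon, gives an at least 10-fold lower number from compound 2 to compound 3 (1.02 log units; beyond the scatter), so at this place a ring of carbon only carrying fluoro returns the series to a measurable value. Fluoro in place of hydroxy on an aromatic carbon gives a 1.1-fold lower number from compound 1 to compound 3 (0.05 log units; within the scatter), which leaves compound 1 and compound 3 indistinguishable on this read-out and shows that the hydroxy group of compound 1 is not required for a value at this level. The true size of the gain from pyridin-3-yl to 2-fluorophenyl stays open at its upper end, because compound 2 is held at a limit and not a number: the limit of > 100000 nM in this assay, at which 1 of the 3 values shown sits.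

The compounds shown do not tell whether any substituent on the ring is needed at all, since a plain phenyl or a methoxy group in place of the fluoro would separate that question from the choice between fluoro and hydroxy. They also leave open whether the ring nitrogen of pyridin-3-yl would cost as much in a pyridin-2-yl or a pyridin-4-yl.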